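The compounds below may be only part of what the source reports. "The series", "measured", "known", "first", "only" and "open" are said of these compounds alone.

Measured so far:
- compound 1 `C[C@@H]1CN(C(=O)c2nc(Nc3cc(C4CC4)[nH]n3)c3cc(Cl)ccc3n2)CCN1C(=O)OCc1ccccc1`; in an assay for inhibition of serine/threonine-protein kinase PAK 4 (Homo sapiens), read by FRET and Z'-LYTE, with a stated time of 60 min, tested at 0.5 uM, in the presence of a further agent that is not named here (on this read-out higher numbers stand for a stronger effect at the one concentration tested and lower numbers for a weaker effect), compound 1 gives 4.4%
- compound 2 `COC(=O)N1CCN(C(=O)c2nc(Nc3cc(C4CC4)[nH]n3)c3cc(Cl)ccc3n2)C[C@H]1C`; compound 2 gives 73.9%
- compound 3 `CCOC(=O)N1CCN(C(=O)c2nc(Nc3cc(C4CC4)[nH]n3)c3cc(Cl)ccc3n2)C[C@H]1C`; compound 3 gives 42.4%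

Compound 2 stands highest of the three numbers. Its nearest neighbour is compound 3, with a number 31.5 percentage points lower from compound 2 to compound 3 (beyond the scatter); the furthest is compound 1, where the step runs a number 69.5 percentage points higher from compound 1 to compound 2 (beyond the scatter).

Compound 4 `CC(C)OC(=O)N1CCN(C(=O)c2nc(Nc3cc(C4CC4)[nH]n3)c3cc(Cl)ccc3n2)C[C@H]1C` is not yet measured. It differs from compound 2 by isopropyl in place of methyl on an oxygen next to a carbonyl group.

All three measured steps bear on this change, since each alters the group on the same oxygen: a number 69.5 percentage points higher from compound 1 to compound 2 (beyond the scatter), a number 38 percentage points higher from compound 1 to compound 3 (beyond the scatter) and a number 31.5 percentage points lower from compound 2 to compound 3 (beyond the scatter). In each case the compound with less on that oxygen gave the higher number, and every step was beyond the scatter. Compound 4 carries isopropyl where compound 2 has methyl, so a drop beyond the scatter is expected, roughly of the size seen in a number 31.5 percentage points lower from compound 2 to compound 3 (beyond the scatter) or somewhat more. For compound 4 the expected step is a number 41.9 percentage points lower from compound 2 to compound 4 (beyond the scatter). Compound 4 is therefore estimated at 32%, within 8% to 56%. Within the data shown here, only three compounds support this trend, so the range is kept wide.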

Compound 4, a percentage reported as inhibition, at one concentration (the size of the read-out at that concentration, not a potency): 26.9%
Beside the measured number, compound 4's estimate is 5.1 percentage points above it; the measured number falls inside the stated range.
By their numbers in this assay, from the lowest: compound 1; then compound 4; then compound 3; then compound 2.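

In this assay, isopropyl on the oxygen next to a carbonyl group continues the fall already seen with ethyl, giving a number 47 percentage points lower from compound 2 to compound 4 (beyond the scatter), and the further methyl on the saturated chain carbon bound to that oxygen still counts, with a number 15.5 percentage points lower from compound 3 to compound 4 (beyond the scatter). Isopropyl nevertheless stays clear of benzyl, with a number 22.5 percentage points higher from compound 1 to compound 4 (beyond the scatter), so the four compounds now fall in the order compound 2, compound 3, compound 4, compound 1, and none goes against the sequence methyl, ethyl, isopropyl, benzyl. No evidence is available on what lies behind this order.

Going by these compounds, whether a longer chain such as n-propyl would match ethyl or isopropyl stays open, so chain length and branching at this carbon remain unseparated. On these data alone, how cyclopropyl or 2-methoxyethyl on the same oxygen would read is also open.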